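Methoxy to Cyano: an Expected Step in Cell Toxicity

The source may hold more compounds than are shown below. What is called first, only, known or untested is meant among the compounds shown, and "the series" means these compounds.

Three compounds sharing one core were tested in a functional assay on PC-12 cells (Rattus norvegicus) for cytotoxicity, read by MTT assay, with stated times of 2 h and 24 h, tested at 5 uM; on this read-out lower numbers stand for a weaker effect and higher numbers for a stronger effect at the one concentration tested. Compound 1 `CC(C)(C)c1ccc(-n2nc(-c3ccc(C(F)(F)F)cc3O)nc2-c2ccccc2O)cc1` gives 77.8% in this assay. Compound 2 `Oc1cc(C(F)(F)F)ccc1-c1nc(-c2ccccc2O)n(-c2ccc(I)cc2)n1` gives 94.4%, and compound 3 `COc1ccc(-n2nc(-c3ccc(C(F)(F)F)cc3O)nc2-c2ccccc2O)cc1` gives 86.6%. Among these three numbers compound 3 stands second highest, and both of its neighbours lie within the scatter: a number 7.8 percentage points lower from compound 2 to compound 3 (within the scatter), and a number 8.8 percentage points higher from compound 1 to compound 3 (within the scatter). For the measured compounds named here, only one step reaches beyond the scatter, namely a number 16.6 percentage points higher from compound 1 to compound 2 (beyond the scatter).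

Compound 4 `N#Cc1ccc(-n2nc(-c3ccc(C(F)(F)F)cc3O)nc2-c2ccccc2O)cc1` has not yet been measured. It differs from compound 3 in one place: cyano in place of methoxy on an aromatic carbon. Two of the measured steps touch this same place, where the methoxy of compound 3 sits and where tert-butyl or iodo stands in the other two, and both of those steps stayed within the scatter. Going by the values given here, no measured compound carries a cyano group, so nothing here shows directly how that group behaves in this assay. On this basis the expected step is a number 1.6 percentage points lower from compound 3 to compound 4 (within the scatter), meaning no change beyond the scatter is expected. Compound 4 is therefore estimated at 85% in this assay, with a range from 70% to 97%.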

Compound 4, a percentage reported as activity, at one concentration (the size of the read-out at that concentration, not a potency): 86.8%
For compound 4 the middle estimate is 1.8 percentage points below the measured one, within the range that was stated.
By their numbers in this assay, from the lowest: compounds 1, 3, 4 and 2 (each within the scatter of the next, the first and the last beyond it).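

The aromatic carbon para to a large group now carries a cyano group, the only nitrile in the series, and in this assay the exchange for methoxy produces a number 0.2 percentage points higher from compound 3 to compound 4 (within the scatter). The comparisons with the two remaining groups at this position also stay inside the scatter, with a number 7.6 percentage points lower from compound 2 to compound 4 (within the scatter) and a number 9 percentage points higher from compound 1 to compound 4 (within the scatter), so compound 4 cannot be separated from any of the other three compounds. For the compounds shown here, the only step at this position that reaches beyond the scatter is still a number 16.6 percentage points higher from compound 1 to compound 2 (beyond the scatter), and the cyano result shows that a nitrile here fits alongside methoxy, without separating from either tert-butyl or iodo.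

Nothing available explains why the change from methoxy to cyano leaves the read-out where it is. Still open, going by these compounds, is how an amine, a carboxylic acid or a longer chain at this position would read in this assay, and whether replacing the trifluoromethyl group elsewhere on the shared core would produce a step beyond the scatter.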